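The source may hold more compounds than are shown below. What is called first, only, known or untested is meant among the compounds shown, and "the series" means these compounds.

Compounds measured in a functional assay on DU-145 cells (Homo sapiens) for inhibition, read by trypan blue exclusion, with a stated time of 96 h; on this read-out higher numbers stand for weaker inhibition of growth and lower numbers for stronger inhibition of growth:

compound 1, `O=C(/C(=C\c1ccc(O)cc1)SCc1ccc(Cl)cc1)c1ccc(Br)cc1`, 10000 nM
compound 2, `O=C(/C(=C\c1ccc(O)cc1)SCc1ccc(F)cc1)c1ccc(Br)cc1`, 10000 nM
compound 3, `O=C(/C(=C\c1ccc(O)cc1)SCc1ccc(F)cc1)c1ccc(Cl)cc1`, 25000 nM

Compound 2 stands level with compound 1 in this assay at the digits shown, and the two together give the lowest numbers of the three. Toward compound 3 the step is a 2.5-fold higher number from compound 2 to compound 3 (0.40 log units; beyond the scatter), a modest rise. The step of no change at the digits printed from compound 1 to compound 2 (within the scatter) shows no change within the scatter.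

Compound 4, `Cc1cc(C)cc(/C=C(/SCc2ccc(F)cc2)C(=O)c2ccc(Br)cc2)c1`, has not yet been measured in this assay. It differs from compound 2 as follows: 3,5-dimethylphenyl in place of 4-hydroxyphenyl on a double-bonded chain carbon bound to a double-bonded chain carbon.

Neither measured step bears on this change. For the measured compounds named here, both concern a halogen swap on an aromatic carbon, while the change to compound 4 replaces the whole 4-hydroxyphenyl at the double-bonded chain carbon with a 3,5-dimethylphenyl; there is no measured pair in this set sharing that change. The expected step of no change at the digits printed from compound 2 to compound 4 (within the scatter) is therefore set near no change, with a wide range to allow for the untested nature of the replacement. For compound 4 the estimate in this assay is 10000 nM, with a range from 2500 nM to 40000 nM.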

Compound 4, concentration for 50% growth inhibition: 10000 nM
Beside the measured number, compound 4's estimate shows no gap at the digits printed; the range from low to high includes it.
By their numbers in this assay, from the lowest: compounds 1, 2 and 4 (each within the scatter of the next); then compound 3.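

In this assay, for the compounds shown here, putting 3,5-dimethylphenyl in place of 4-hydroxyphenyl on a double-bonded chain carbon bound to a double-bonded chain carbon gives no change at the digits printed from compound 2 to compound 4 (within the scatter), the first reading at this position, which the earlier halogen swaps left untouched. The hydroxyl of compound 2 is therefore not required to hold the number at this level, at least with the rest of compound 2 in place, as the entering group in compound 4 has 0 hydrogen-bond donors and 0 hydrogen-bond acceptors. Nothing measured here accounts for the two groups reading alike.

The change removes the hydroxyl and adds two methyl groups in a single step, so the compounds shown cannot separate the two, and a plain phenyl, a 4-methoxyphenyl, a 4-aminophenyl or a 4-carboxyphenyl at this position remains an open question. From the compounds shown here alone, it is also open whether the 3,5-dimethylphenyl would read the same way in the chloro-bearing setting of compound 3, or with the chloro on the other ring as in compound 1.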